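The compounds below may be only part of what the source reports. "The series", "measured", "known", "first", "only" and "open" are said of these compounds alone.

Of the compounds shown here, three built on one shared core have been tested in a functional assay on SK-BR-3 cells (Homo sapiens) for antiproliferative activity, read by MTT assay, with a stated time of 72 h; a higher number here means a weaker inhibitor, a lower number a stronger inhibitor. Compound 1 `C/C=C1/[C@H](O[C@@H]2O[C@H](CO)[C@@H](O)[C@H](O)[C@H]2O)OC=C(C(=O)O)[C@H]1CC(=O)OC` reaches only the limit of the assay, > 20000 nM, so no number is known for it. Compound 2 `C/C=C1/[C@H](O[C@@H]2O[C@H](CO)[C@@H](O)[C@H](O)[C@H]2O)OC=C(C(=O)OC)[C@H]1CC(=O)O` likewise gives only a limit, > 15000 nM. Compound 3 `C/C=C1/[C@H](O[C@@H]2O[C@H](CO)[C@@H](O)[C@H](O)[C@H]2O)OC=C(C(=O)OC)[C@H]1CC(=O)OCCCc1ccc(OC)c(OC)c1` also stops at a limit, > 20000 nM. On the numbers shown, compound 3 therefore stands alongside the others: none of the three has a measured value, compound 3 shares the limit of > 20000 nM in this assay, at which 2 of the 3 values shown sit, with compound 1, and compound 2 sits at the limit of > 15000 nM in this assay, at which 1 of the 3 values shown sits.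

Compound 4 `C/C=C1/[C@H](O[C@@H]2O[C@H](CO)[C@@H](O)[C@H](O)[C@H]2O)OC=C(C(=O)OC)[C@H]1CC(=O)OC` has not yet been measured. It differs from compound 3 in a single place: hydrogen in place of 2-(3,4-dimethoxyphenyl)ethyl on a saturated chain carbon bound to an oxygen next to a carbonyl group. Among the measured compounds shown here, no pair of measured compounds differs in one place, and no step of known size can be carried over to this change. For the measured compounds named here, every compound measured so far lies beyond the reach of the assay. The expected step from compound 3 to compound 4 is a step that the limit leaves unreadable from compound 3 to compound 4, which is to say none beyond the usual scatter. Compound 4 is estimated to give 25000 nM in this assay. Its expected range runs from 10000 nM to 60000 nM, and the most likely outcome is once more only a limit rather than a number.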

Compound 4, half-maximal inhibitory concentration: > 15000 nM
Compound 4 gave a limit, no number; the forecaster's own chance of this, stated with the estimate: 85%; the middle value lies beyond the limit too.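

In this assay compound 4 gives > 15000 nM, which is a limit and not a number. Among the compounds shown here, all four compounds stop at such limits, so no step from compound 1, compound 2 or compound 3 to compound 4 can be read. The compounds shown leave open whether any of these changes to the shared core alters activity at all.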